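Chain lengthening in the shared core, heptyl to octyl

This account rests on a few compounds, and the source may have more. Where it says the series, first, only, none or still open, it means among the compounds named here.

Compound 1 `C=CC(=O)c1ccc(CCC)cc1` reaches only a limit, > 100000 nM, in an assay on isolated protein for displacement of a labelled ligand from thyroid hormone receptor alpha (Homo sapiens), read by fluorescence polarization; on this read-out lower numbers stand for stronger inhibition and higher numbers for weaker inhibition. Among the compounds with values here, compound 2 `C=CC(=O)c1ccc(CCCCCCC)cc1` gives 23000 nM in this assay and is thus the only compound of the pair with a number rather than a limit (the limit of > 100000 nM in this assay, at which 1 of the 2 values shown sits). The step of an at least 4.3-fold lower number from compound 1 to compound 2 (0.63 log units; beyond the scatter) points toward a benefit from a longer chain, although its true size is open since one end rests on a limit. Compound 3 `C=CC(=O)c1ccc(CCCCCCCC)cc1` differs from compound 2 by methyl in place of hydrogen on a saturated chain carbon, seven bonds along the chain from an aromatic carbon. Within the data shown here, only one measured step bears on this change, an at least 4.3-fold lower number from compound 1 to compound 2 (0.63 log units; beyond the scatter), and it describes a larger addition to a shorter chain, so a smaller effect, if any, would follow for a single methyl added to an already long chain. Compound 3 is therefore expected to give about 15000 nM in this assay, within 6000 nM to 40000 nM, an estimated step of a 1.5-fold lower number from compound 2 to compound 3 (0.19 log units; within the scatter) that stays within the scatter.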

Compound 3, half-maximal inhibitory concentration: 21400 nM
Estimate against measurement, compound 3: 1.4-fold (0.15 log units) below, and the stated range covers the measured number.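

In this assay, methyl in place of hydrogen on a saturated chain carbon, seven bonds along the chain from an aromatic carbon, gives a 1.1-fold lower number from compound 2 to compound 3 (0.03 log units; within the scatter), so heptyl and octyl on the shared core cannot be told apart. The gain seen with the earlier chain extension is therefore not visibly carried further at this length, although the full extension reads an at least 4.6-fold lower number from compound 1 to compound 3 (0.66 log units; beyond the scatter). The true size of that full step stays open, since compound 1 rests on a limit: the limit of > 100000 nM in this assay, at which 1 of the 3 values shown sits.

Still open, on these data alone, is whether a longer chain, such as decyl or dodecyl, would move the number beyond the scatter, and at which chain length between propyl and heptyl the drop arises. Also open, as far as these compounds go, is how an amine or a carboxylic acid on the chain would read.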